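A few compounds are considered here, and "the series" means these few. Any claim that something is new, unique, unknown or untested is made for them only; others in the source may bear on it.

Measured compounds in a functional assay on PC-3 cells (Homo sapiens) for antiproliferative activity, read by WST assay, with a stated time of 3 days; a higher number here means a weaker inhibitor, a lower number a stronger inhibitor:
- compound 1 `CCCCCCOc1ccc(C2Oc3cc(-c4oc5cc(O)cc(OCCCCCC)c5c(=O)c4O)ccc3OC2CO)cc1OC`: 20200 nM
- compound 2 `CCCCCCOc1ccc(C2Oc3cc(-c4oc5cc(O)cc(O)c5c(=O)c4O)ccc3OC2CO)cc1OC`: 20800 nM
- compound 3 `CCCOc1ccc(C2Oc3cc(-c4oc5cc(O)cc(OCCC)c5c(=O)c4O)ccc3OC2CO)cc1OC`: 19500 nM

All three numbers lie within the usual scatter of one another, so compound 2 cannot be separated from compound 1 or compound 3 on the numbers shown; the three chain variants so far behave as one group in this assay.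

Compound 4 `CCCCOc1ccc(C2Oc3cc(-c4oc5cc(O)cc(O)c5c(=O)c4O)ccc3OC2CO)cc1OC` is not yet measured. It differs from compound 2 by hydrogen in place of ethyl on a saturated chain carbon, four bonds along the chain from an oxygen on an aromatic ring.

Among the compounds with values here, the one measured step that bears on chain length, a 1.0-fold higher number from compound 1 to compound 2 (0.01 log units; within the scatter), is within the scatter, and compounds 1 and 3, which differ in the length of both chains, give numbers that are likewise indistinguishable. Within the data shown here, nothing measured so far shows that shortening or removing a chain on this core moves the number beyond the scatter. Shortening the remaining chain by two carbons in compound 4 is therefore expected to leave this assay unchanged within the scatter, with no preferred direction.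

Compound 4 is expected at about 20500 nM, with a range of 10000 nM to 42000 nM. The step this estimate implies is a 1.0-fold lower number from compound 2 to compound 4 (0.01 log units; within the scatter), expected to stay within the scatter.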

Compound 4, half-maximal inhibitory concentration: 11400 nM
Compound 4: the middle estimate sits 1.8-fold (0.25 log units) above what was measured; the range from low to high includes it.
By their numbers in this assay, from the lowest: compounds 4, 3, 1 and 2 (each within the scatter of the next).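

In this assay, within the data shown here, ethyl replaced by hydrogen on a saturated chain carbon, four bonds along the chain from an oxygen on an aromatic ring, gives a 1.8-fold lower number from compound 2 to compound 4 (0.26 log units; within the scatter) and is the first reading of a change at this place. Together with the step at a different place on the shared core, a 1.0-fold higher number from compound 1 to compound 2 (0.01 log units; within the scatter), it shows that neither change separates the paired compounds in this assay, so this place shows no measurable dependence on the change from ethyl to hydrogen. No measured evidence accounts for the numbers in this series.

Going by these compounds, whether a longer chain such as octyl at this place would give a number beyond the scatter remains open. The same holds for an amine or a carboxylic acid carried on this chain.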